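The compounds below may be only part of what the source reports. "The series", "measured", "known", "first", "only" and "open" are said of these compounds alone.

Compound 1: `CNC(=O)N1CCCc2ccc(NC(=O)c3cccc(-c4cn[nH]c4)c3)cc21`, 77.7%. Compound 2: `CNC(=O)N1CCCc2ccc(NC(=O)c3cccc(-c4cc[nH]n4)c3)cc21`, 89.7%. Both were tested in a functional assay on MV4-11 cells (Homo sapiens) for antiproliferative activity, with a stated time of 6 days, tested at 6.25 uM; a higher number here means a stronger effect of the compound at the concentration tested, a lower number a weaker effect.

Within the data shown here, on these two numbers compound 2 stands highest, with compound 1 as its only neighbour, and the gap is a number 12 percentage points higher from compound 1 to compound 2 (beyond the scatter). Compound 3, `CNC(=O)N1CCCc2ccc(NC(=O)c3cccc(-c4cnn(S(C)(=O)=O)c4)c3)cc21`, is not yet measured; it differs from compound 2 as follows: 1-(methylsulfonyl)-1H-pyrazol-4-yl in place of 1H-pyrazol-3-yl on an aromatic carbon. Among the measured compounds shown here, the one step that bears on it is the earlier one, which ran the other way between the two pyrazole attachments and gave a number 12 percentage points higher from compound 1 to compound 2 (beyond the scatter). Returning to the 1H-pyrazol-4-yl attachment, now carrying the methylsulfonyl, is therefore expected to cost a modest amount, estimated as a number 17.7 percentage points lower from compound 2 to compound 3 (beyond the scatter), with the methylsulfonyl's own effect unknown. For compound 3 the expected value is 72%, between 45% and 92%.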

Compound 3, a percentage reported as inhibition, at one concentration (the size of the read-out at that concentration, not a potency): 18%
Compound 3: middle estimate off by 54 percentage points, on the high side; measured number outside the range, below it.
By their numbers in this assay, from the lowest: compound 3; then compound 1; then compound 2.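

On the pyrazole nitrogen, methylsulfonyl in place of hydrogen gives a number 59.7 percentage points lower from compound 1 to compound 3 (beyond the scatter) and is a large step, so that nitrogen tolerates this change poorly even though both unsubstituted pyrazoles stay high. Read against the better attachment, the full swap to 1-(methylsulfonyl)-1H-pyrazol-4-yl gives a number 71.7 percentage points lower from compound 2 to compound 3 (beyond the scatter) and loses most of the effect at this aromatic carbon. Nothing measured here explains the drop. As far as these compounds go, whether a plain methyl or an acetyl on that nitrogen would lose as much remains open. So does whether methylsulfonyl on the 1H-pyrazol-3-yl attachment would behave the same way.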